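Substituents on the aryl ring of the shared core

The source may report more compounds than this note shows. Statements on the series, on what has been measured and on what is new or still open speak of the compounds shown alone.

Measured so far:
compound 1, `Cc1nn(C)c2c1C(c1ccccc1)=NCCN2`, 2.5 mg/kg
compound 2, `Cc1nn(C)c2c1C(c1cccc(C(F)(F)F)c1)=NCCN2`, 0.63 mg/kg
compound 3, `Cc1nn(C)c2c1C(c1cccc(O)c1)=NCCN2`, 2.5 mg/kg

In a functional assay on the whole organism for positive allosteric modulation, with Rattus norvegicus as the target (a lower number here means that less compound is needed, a higher number that more compound is needed for the effect), compound 1 stands level with compound 3 at the digits given, the two together the highest numbers of the three; compound 2 lies furthest off, with a 4.0-fold lower number from compound 1 to compound 2 (0.60 log units; beyond the scatter). Compound 4, `COc1ccc(C2=NCCNc3c2c(C)nn3C)cc1`, differs from compound 1 by methoxy in place of hydrogen on an aromatic carbon. Within the data shown here, no measured step puts a group on that carbon of the ring. Among the measured compounds shown here, the steps that bear on it sit on another aromatic carbon: a 4.0-fold lower number from compound 1 to compound 2 (0.60 log units; beyond the scatter), beyond the scatter, and no change at the digits printed from compound 1 to compound 3 (within the scatter), within it. For the measured compounds named here, with no direct precedent for the methoxy, no step beyond the scatter is expected in this assay, that is a 1.3-fold lower number from compound 1 to compound 4 (0.10 log units; within the scatter). Compound 4 is therefore estimated at 2 mg/kg, ranging from 0.8 mg/kg to 5 mg/kg.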

Compound 4, minimum effective dose: > 10 mg/kg
Compound 4: only a limit was reported; the forecaster's own chance of this, stated with the estimate: 5%; middle value at least 5.0-fold (0.69 log units) away from the limit.
By their numbers in this assay, from the lowest: compound 2; then compounds 1 and 3 (each within the scatter of the next). At a limit, above all of these: compound 4.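

In this assay, compound 4 gives > 10 mg/kg, which is a limit of the assay and not a number. Methoxy para to a large group gives an at least 4.0-fold higher number from compound 1 to compound 4 (0.60 log units; beyond the scatter), the only step from compound 1 toward a higher number among the compounds shown. Trifluoromethyl and hydroxy, on another aromatic carbon, gave no such rise, and the size of this one stays bounded: the limit of > 10 mg/kg in this assay, at which 1 of the 4 values shown sits.

On these data alone, whether the rise follows this carbon or the methoxy group remains open. A methyl, a fluorine or an amine on this carbon, or methoxy on the other aromatic carbon, would separate the two.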